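A few compounds are considered here, and "the series" means these few. Any claim that something is new, unique, unknown or untested is made for them only; others in the source may bear on it.

Compound 1 `CCN(CC)C(=O)Cn1c(=O)c(-c2ccc(OC)cc2)cc2c(OC)cc(OC)cc21`: 10000 nM
Compound 2 `COc1ccc(-c2cc3c(OC)cc(OC)cc3n(CCCC#N)c2=O)cc1`: 10000 nM

In a functional assay on T-24 cells (Homo sapiens) for cytotoxicity, read by colorimetric assay and MTT assay (on this read-out lower numbers stand for stronger inhibition and higher numbers for weaker inhibition), compound 2 gives 10000 nM, level with compound 1 at 10000 nM. Compound 3 `CCN(CC)C(=O)CCn1c(=O)c(-c2ccc(OC)cc2)cc2c(OC)cc(OC)cc21` differs from compound 2 as follows: diethylcarbamoyl in place of cyanomethyl on a saturated chain carbon, two bonds along the chain from an aromatic nitrogen. Its side chain thus becomes 2-(diethylcarbamoyl)ethyl. Going by the values given here, the one measured step that bears on this change is no change at the digits printed from compound 1 to compound 2 (within the scatter), and it stays within the scatter. That single step is thin evidence, but it points to no clear direction. The expected step in this assay is no change at the digits printed from compound 2 to compound 3 (within the scatter), with none expected beyond the scatter. For compound 3 the estimate is 10000 nM, with an expected range from 4000 nM to 25000 nM.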

Compound 3, half-maximal inhibitory concentration: 10000 nM
Beside the measured number, compound 3's estimate shows no gap at the digits printed; the range from low to high includes it.
By their numbers in this assay, from the lowest: compounds 1, 2 and 3 (each within the scatter of the next).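

Placing diethylcarbamoyl in place of cyanomethyl, on a saturated chain carbon two bonds along the chain from an aromatic nitrogen, gives no change at the digits printed from compound 2 to compound 3 (within the scatter) in this assay. Set against the (diethylcarbamoyl)methyl chain, the 2-(diethylcarbamoyl)ethyl chain gives no change at the digits printed from compound 1 to compound 3 (within the scatter), so the amide now stands on two chain lengths with the same printed number. Nothing available explains why these groups read alike. On these data alone, whether an amine or a carboxylic acid at the end of this chain would separate from these compounds remains open. So does the effect of any change on the shared core.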